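A few compounds are considered here, and "the series" means these few. Any claim that something is new, unique, unknown or untested is made for them only; others in the source may bear on it.

Measured so far in a functional assay on HUVEC cells (Homo sapiens) for inhibition, with a stated time of 4 days; a higher number here means a weaker inhibitor, a lower number a stronger inhibitor:
Compound 1 `COc1ccc(C(N)=O)cc1/C=C/c1cccc(Cl)c1`: 24000 nM
Compound 2 `COc1ccc(C(N)=O)cc1/C=C/c1ccc(Cl)cc1F`: 1700 nM
Compound 3 `CCOc1ccc(C(N)=O)cc1/C=C/c1ccc(Cl)cc1`: 190 nM

Of these three, compound 3, at 190 nM, has the lowest number and is the strongest inhibitor in this assay. Its gaps to the other two both lie beyond the scatter, with compound 2 nearest at 1700 nM and compound 1 furthest at 24000 nM. For the measured compounds named here, the three differ from one another in more than one place, so the data isolate no single structural step.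

Compound 4 `NC(=O)c1ccc(OCCOCCO)c(/C=C/c2ccc(Cl)cc2)c1` has not yet been measured. It extends the ethoxy of compound 3 to 2-(2-hydroxyethoxy)ethoxy: 2-hydroxyethoxy in place of hydrogen on a saturated chain carbon, two bonds along the chain from an oxygen on an aromatic ring. Going by the values given here, no measured compound carries a chain of this kind, so the data offer no direct precedent for the change. The expectation therefore starts from compound 3 at 190 nM, and a modest move towards weaker inhibition in this assay is expected, one that may not clearly exceed the scatter. The expected size of this move is a 1.8-fold higher number from compound 3 to compound 4 (0.27 log units; within the scatter). For compound 4 the estimated value is 350 nM, with an expected range of 70 nM to 1800 nM.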

Compound 4, half-maximal inhibitory concentration: 11000 nM
Estimate against measurement, compound 4: 31-fold (1.50 log units) below; measured number above the stated range.
By their numbers in this assay, from the lowest: compound 3; then compound 2; then compound 4; then compound 1.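

In this assay, extending the ethoxy of the shared core to 2-(2-hydroxyethoxy)ethoxy gives a 58-fold higher number from compound 3 to compound 4 (1.76 log units; beyond the scatter) and so costs a large amount of inhibition: on this saturated chain carbon, two bonds along the chain from an oxygen on an aromatic ring, 2-hydroxyethoxy in place of hydrogen is far from a neutral change. The earlier compounds differed from one another in more than one place, so this is the only comparison shown that isolates a single change, and it makes clear that the outcome in this assay depends strongly on what this chain carries. No measurement accompanies the result that would account for the size of this step.

The compounds shown leave open whether the loss follows from the added length of the chain or from its hydroxyl, a distinction that a 2-methoxyethoxy or a plain butoxy chain at the same oxygen would address. On these data alone, it also remains open whether a shorter 2-hydroxyethoxy group, or a chain ending in an amine or a carboxylic acid, would behave in the same way.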